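A few compounds are considered here, and "the series" means these few. Any claim that something is new, unique, unknown or untested is made for them only; others in the source may bear on it.

Measured in a functional assay on DU-145 cells (Homo sapiens) for inhibition, read by trypan blue exclusion, with a stated time of 96 h; a lower number here means a stronger inhibitor of growth, a higher number a weaker inhibitor of growth:

- compound 1 `Cc1ccsc1/C=C(/SCc1ccc(Cl)cc1)C(=O)c1ccc(Cl)cc1`: 50000 nM
- compound 2 `Cc1ccc(/C=C(/SCc2ccc(Cl)cc2)C(=O)c2ccc(Cl)cc2)s1`: 50000 nM
- compound 3 `Cc1cc(C)cc(/C=C(/Sc2ccc(Br)cc2)C(=O)c2ccc(Cl)cc2)c1`: 10000 nM

Of these three, compound 3 has the lowest number, and it stands beyond the scatter from both of the others. The next compound, compound 4 `Cc1cc(C)cc(/C=C(/SCc2ccc(Cl)cc2)C(=O)c2ccc(Cl)cc2)c1`, keeps everything in compound 3 except the group on sulfur, where 4-chlorobenzyl takes the place of 4-bromophenyl: 4-chlorobenzyl in place of 4-bromophenyl on a sulfur.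

For the measured compounds named here, the only measured step, no change at the digits printed from compound 1 to compound 2 (within the scatter), changes another part of the molecule and leaves the group on sulfur untouched. It therefore says little about this change, beyond showing one alteration elsewhere that left the number as it was. Going by the values given here, no measured pair isolates a swap on sulfur. The closest evidence is indirect: compound 1 at 50000 nM and compound 2 at 50000 nM both carry the incoming 4-chlorobenzyl on sulfur, and both have higher numbers than compound 3 at 10000 nM. Those two also differ from compound 3 in the other aryl group, so the comparison is loose.

A weaker growth inhibitor is therefore expected, with an estimated step of a 2.5-fold higher number from compound 3 to compound 4 (0.40 log units; beyond the scatter). For compound 4 the expected value is 25000 nM, with an estimated range from 8000 nM to 60000 nM.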

Compound 4, concentration for 50% growth inhibition: 10000 nM
The estimate for compound 4 lay 2.5-fold (0.40 log units) above the measured number; measured number inside the range.
By their numbers in this assay, from the lowest: compounds 3 and 4 (each within the scatter of the next); then compounds 1 and 2 (each within the scatter of the next).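

Swapping 4-bromophenyl for 4-chlorobenzyl on the sulfur gave (no change at the digits printed from compound 3 to compound 4 (within the scatter)) in this assay, so the first direct reading at this position shows no separation between these two groups. With 4-chlorobenzyl held on the sulfur, 3,5-dimethylphenyl on the double-bonded chain carbon gave (a 5.0-fold lower number from compound 2 to compound 4 (0.70 log units; beyond the scatter)) in place of 5-methylthiophen-2-yl and (a 5.0-fold lower number from compound 1 to compound 4 (0.70 log units; beyond the scatter)) in place of 3-methylthiophen-2-yl. Among these compounds, the gap between compound 3 and the two thiophene compounds therefore goes with the aryl group on that chain carbon and not with the group on sulfur, although nothing measured here accounts for either result.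

The swap on sulfur alters the halogen and the link to the ring together, so the separate contribution of each stays unresolved, and 4-chlorophenyl or 4-bromobenzyl on the sulfur would be needed to tell them apart. Going by these compounds, it also remains open whether this tolerance extends to a group on sulfur that carries an amine or a carboxylic acid, or to a longer chain between the sulfur and the ring.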